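From 1,3-thiazol-4-yl to pyrimidin-2-yl on the shared core

This account rests on a few compounds, and the source may have more. Where it says the series, first, only, none or still open, it means among the compounds named here.

In an in vivo ADME assay on the whole organism (strain 129/SvEvBrd x C57BL/6) for pharmacokinetics, with Mus musculus as the target (a higher number here means that a larger share of the oral dose reaches the circulation, a lower number that a smaller share of the oral dose reaches the circulation), compound 3 `OC[C@@H](O)[C@@H](O)[C@H](O)c1c[nH]c(-c2cscn2)n1` gives 12% and so lies within the scatter of compound 1 `CC(=O)c1nc([C@@H](O)[C@H](O)[C@H](O)CO)c(C)[nH]1` at 11% while compound 2 `Cc1nc(-c2nc([C@@H](O)[C@H](O)[C@H](O)CO)c[nH]2)cs1` gives 23% in the same measurement. Compound 4 `OC[C@@H](O)[C@@H](O)[C@H](O)c1c[nH]c(-c2ncccn2)n1` carries pyrimidin-2-yl in place of 1,3-thiazol-4-yl on an aromatic carbon, between two ring nitrogen atoms pyrimidin-2-yl in place of 1,3-thiazol-4-yl on an aromatic carbon and the rest of the structure stays as it is in compound 3. Among the measured compounds shown here, one measured step bears on this position: hydrogen in place of methyl on an aromatic carbon of the 1,3-thiazol-4-yl group gave a number 11 percentage points lower from compound 2 to compound 3 (beyond the scatter) as its result. That step is modest, and it leaves the group itself in place. For the measured compounds named here, no measured step exchanges the whole group, so the data give no direction for this change. The expected step is a number 2 percentage points higher from compound 3 to compound 4 (within the scatter) and no shift beyond the scatter is estimated. For compound 4 the estimate is 14% with an expected range from 5% to 28% in this assay for now.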

Compound 4, oral bioavailability: 7%
The estimate for compound 4 lay 7 percentage points above the measured number; low and high end bracket the measured number.
By their numbers in this assay, from the lowest: compounds 4, 1 and 3 (each within the scatter of the next); then compound 2.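

In this assay the exchange of the whole group at this position now has a measured result: pyrimidin-2-yl in place of 1,3-thiazol-4-yl gives a number 5 percentage points lower from compound 3 to compound 4 (within the scatter) and so does not separate the six-membered ring from the five-membered ring. Set against the 2-methyl-1,3-thiazol-4-yl group, the same pyrimidin-2-yl group gives a number 16 percentage points lower from compound 2 to compound 4 (beyond the scatter) and thus places the 2-methyl-1,3-thiazol-4-yl group of compound 2 clear of both other groups at this place. Nothing at hand gives a reason for these numbers.

In this assay the compounds shown leave open whether a methyl group on the pyrimidin-2-yl ring would change the number as it does on the 1,3-thiazol-4-yl ring. They also leave open how an amine or a methoxy group on that ring would read.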